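Changing the Benzyl Substituent on a Weakly Active Amide

The source may hold more compounds than are shown below. What is called first, only, known or untested is meant among the compounds shown, and "the series" means these compounds.

Compound 1 has the structure `COc1ccc(CNC(=O)/C(C#N)=C/c2ccc[nH]2)cc1` and compound 2 has the structure `COc1ccc(CNC(=O)/C(C#N)=C/c2ccc3ccccc3c2)cc1`; both carry an amide whose nitrogen is attached through a saturated chain carbon to a 4-methoxyphenyl group, and they differ in the aromatic part on the far side of the core. For the measured compounds named here, in a functional assay on HT-29 cells (Homo sapiens) for inhibition, read by MTT assay, with a stated time of 72 h (on this read-out lower numbers stand for stronger inhibition of growth and higher numbers for weaker inhibition of growth), compound 2 gives 54000 nM, which is the only actual number reported, and it stands for weak inhibition of growth. For compound 1 this assay reports only a limit, > 50000 nM, as described by the limit of > 50000 nM in this assay, at which 1 of the 2 values shown sits.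

Compound 3, `N#C/C(=C\c1ccc2ccccc2c1)C(=O)NCc1ccc(Cl)c(Cl)c1`, keeps the core of compound 2 and differs from it in one place: 3,4-dichlorophenyl in place of 4-methoxyphenyl on a saturated chain carbon bound to an amide-type nitrogen. Going by the values given here, no measured pair shows this change, so there is no step to lean on. The expected step from this change is small and of uncertain direction, probably not clearly beyond the usual scatter. The estimated step of a 1.4-fold lower number from compound 2 to compound 3 (0.13 log units; within the scatter) expresses that expectation. In this assay compound 3 is expected to give about 40000 nM, with a range from 10000 nM to 120000 nM.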

Compound 3, concentration for 50% growth inhibition: 44000 nM
For compound 3 the middle estimate is 1.1-fold (0.04 log units) below the measured one; the measured number falls inside the stated range.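

For the compounds shown here, this is the first measured pair that changes this position, as the earlier compounds differed only in the aromatic part on the far side of the core. In this assay, putting 3,4-dichlorophenyl in place of 4-methoxyphenyl on a saturated chain carbon bound to an amide-type nitrogen gives a 1.2-fold lower number from compound 2 to compound 3 (0.09 log units; within the scatter), so the two compounds cannot be told apart. The exchange removes the 1 hydrogen-bond acceptor of the leaving group and swaps its oxygen and one carbon for two chlorines, yet in this one pair inhibition of growth stays weak, and compound 1 adds only a limit, not a number: the limit of > 50000 nM in this assay, at which 1 of the 3 values shown sits.

Still open, on these data alone, is whether any group at this position can move the number beyond the scatter, for example an amine or a carboxylic acid on the phenyl ring, or a longer chain carrying that ring. Also open, as far as these compounds go, is whether 3,4-dichlorophenyl would behave the same way with a different aromatic part on the far side of the core, since this single pair speaks only for the core of compound 2.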